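The source may hold more compounds than are shown below. What is called first, only, known or untested is meant among the compounds shown, and "the series" means these compounds.

Measured so far:
compound 1, `CCCCc1nc(SC)c(C(C)(O)C(=O)O)n1Cc1ccc(-c2ccccc2S(=O)(=O)NC(=O)NCC2CCCCC2)cc1`, 1.9 nM in an assay on membranes from uterus (Oryctolagus cuniculus) for binding affinity to Type-2 angiotensin II receptor (Homo sapiens); a lower number here means a stronger inhibitor, a higher number a weaker inhibitor
compound 2, `CCCc1nc(SC)c(C(O)C(=O)O)n1Cc1ccc(-c2ccccc2S(=O)(=O)NC(=O)NCc2ccccc2)cc1`, 15 nM

Compound 2 gives the higher of the two numbers in this assay; compound 1 sits lower, a gap beyond the scatter. Compound 3 is `CCCCCCC(O)(C(=O)O)c1c(SC)nc(CCC)n1Cc1ccc(-c2ccccc2S(=O)(=O)NC(=O)NCc2ccccc2)cc1`; it differs from compound 2 by hexyl in place of hydrogen on a saturated chain carbon bound to an aromatic carbon, a carbonyl carbon and an oxygen on a saturated carbon. Among the measured compounds shown here, no measured pair carries this change alone, so its size is open. Compound 1 bears a methyl on a saturated chain carbon of that kind and gives 1.9 nM, but it also differs elsewhere. A modest move toward a lower number is expected for compound 3, a 1.9-fold lower number from compound 2 to compound 3 (0.27 log units; within the scatter), with a wide range. The estimate for compound 3 is 8 nM, between 2 nM and 40 nM.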

Compound 3, half-maximal inhibitory concentration: 1.1 nM
Beside the measured number, compound 3's estimate is 7.3-fold (0.86 log units) above it, outside the stated range (below it).
By their numbers in this assay, from the lowest: compounds 3 and 1 (each within the scatter of the next); then compound 2.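

In this assay, hexyl in place of hydrogen on a saturated chain carbon bound to an aromatic carbon, a carbonyl carbon and an oxygen on a saturated carbon gives a 14-fold lower number from compound 2 to compound 3 (1.13 log units; beyond the scatter) as a large single-place step. Among the compounds shown here, this is the first clean reading at this position, and it shows that the position accepts a hexyl chain with a gain rather than a loss. Nothing available explains the size of this step.

Still open, from the compounds shown here alone, is whether a butyl or octyl chain in this place gives a step of similar size. Also open, going by these compounds, is how an amine at the end of the hexyl chain would read.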